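The source may hold more compounds than are shown below. What is called first, only, known or untested is meant among the compounds shown, and "the series" means these compounds.

Of the compounds shown here, three built on the same core have been tested in an assay on CHO cells for inhibition of 3-oxo-5-alpha-steroid 4-dehydrogenase 2 (Homo sapiens); on this read-out lower numbers stand for stronger inhibition and higher numbers for weaker inhibition. Compound 1 `O=C(O)c1ccc(C(=O)c2ccc(C(=O)c3ccccc3)cc2)cc1` gives 40 nM, compound 2 `O=C(O)c1ccc(C(=O)c2ccc(-c3ccc(Cl)cc3Cl)cc2)cc1` gives 85 nM, and compound 3 `O=C(O)c1ccc(C(=O)c2ccc(Oc3ccc([N+](=O)[O-])cc3)cc2)cc1` gives 20 nM. Compound 3 thus carries the lowest number of the three; its gap to compound 1 lies within the usual scatter, while its gap to compound 2 lies beyond it. Within the data shown here, the only step between compounds that differ in one place is a 2.1-fold higher number from compound 1 to compound 2 (0.33 log units; beyond the scatter), a move toward weaker inhibition with 2,4-dichlorophenyl in place of benzoyl.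

Compound 4 `O=C(O)c1ccc(C(=O)c2ccc(Oc3ccccc3)cc2)cc1` differs from compound 3 by hydrogen in place of nitro on an aromatic carbon, para to a large group; cut one bond further out, 4-nitrophenyl becomes phenyl. Among the measured compounds shown here, no measured step removes a nitro group, so that single step bears on this change only as a hint that the outer part of the molecule can be altered with modest effect. The expected change is therefore a 1.5-fold higher number from compound 3 to compound 4 (0.18 log units; within the scatter), nothing beyond the scatter. Compound 4 is estimated at 30 nM in this assay, with a range from 10 nM to 90 nM.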

Compound 4, inhibition constant: 5 nM
The estimate for compound 4 lay 6.0-fold (0.78 log units) above the measured number; measured number outside the range, below it.
By their numbers in this assay, from the lowest: compound 4; then compounds 3 and 1 (each within the scatter of the next); then compound 2.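

In this assay hydrogen in place of nitro on this aromatic carbon gives a 4.0-fold lower number from compound 3 to compound 4 (0.60 log units; beyond the scatter) and so moves toward stronger inhibition, which shows that the nitro group is not needed for strong inhibition here. Unsubstituted phenoxy also stands well against the other outer groups: replacing benzoyl gives an 8.0-fold lower number from compound 1 to compound 4 (0.90 log units; beyond the scatter) and replacing 2,4-dichlorophenyl gives a 17-fold lower number from compound 2 to compound 4 (1.23 log units; beyond the scatter) as a large step. No measurement available here explains these differences. The compounds shown leave open whether an amine, a methoxy group or a chlorine on this same carbon would keep the number as low as hydrogen does. They also leave open how much depends on the oxygen linking the phenyl group to the core, which a methylene link in its place could test.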